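Phenoxymethyl for trifluoromethyl on the aryl amine of the amidoxime series

This account rests on a few compounds, and the source may have more. Where it says the series, first, only, none or still open, it means among the compounds named here.

Measured so far in an assay on tissue (HeLa cells) for inhibition of Indoleamine 2,3-dioxygenase 1 (Homo sapiens), read by spectrophotometry; a lower number here means a stronger inhibitor, a higher number a weaker inhibitor:
compound 1 `O/N=C(/Nc1cccc(Cl)c1)c1ccc2occc2c1` gives 1500 nM
compound 2 `O/N=C(/Nc1cccc(C(F)(F)F)c1)c1ccc2occc2c1` gives 1900 nM
compound 3 `O/N=C(/Nc1ccc(F)c(C(F)(F)F)c1)c1ccc2occc2c1` gives 2200 nM

Compound 2 stands second highest of the three numbers; its nearest neighbour is compound 3 at a 1.2-fold higher number from compound 2 to compound 3 (0.06 log units; within the scatter), its furthest compound 1, and both gaps lie within the scatter. The three compounds therefore cannot be ordered in this assay.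

Compound 4 `O/N=C(/Nc1cccc(COc2ccccc2)c1)c1ccc2occc2c1` is not yet measured. It differs from compound 2 as follows: phenoxymethyl in place of trifluoromethyl on an aromatic carbon.

Among the compounds with values here, two measured steps touch the same ring. The step from compound 1 to compound 2, a 1.3-fold higher number from compound 1 to compound 2 (0.10 log units; within the scatter), and the step from compound 2 to compound 3, a 1.2-fold higher number from compound 2 to compound 3 (0.06 log units; within the scatter), were both within the scatter, so the small substituent changes so far have not moved the number. Neither step, however, covers the entry of a group of the size of phenoxymethyl, so its effect is not anchored by the data.

With that in mind the number for compound 4 in this assay is expected to stay near that of compound 2, a step of about a 1.4-fold lower number from compound 2 to compound 4 (0.13 log units; within the scatter), with a wide range. The estimate for compound 4 is 1400 nM, between 400 nM and 4500 nM.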

Compound 4, half-maximal inhibitory concentration: > 30000 nM
Compound 4 ended at the assay's limit; the forecaster's own chance of this, stated with the estimate: 5%; middle value at least 21-fold (1.33 log units) away from the limit.
By their numbers in this assay, from the lowest: compounds 1, 2 and 3 (each within the scatter of the next). At a limit, above all of these: compound 4.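

Compound 4 stands at a limit of this assay, not at a number: the limit of > 30000 nM in this assay, at which 1 of the 4 values shown sits.

Chloro and trifluoromethyl at this place gave values within the scatter of each other, but that flat reading does not extend to phenoxymethyl, which gives an at least 15-fold higher number from compound 2 to compound 4 (1.19 log units; beyond the scatter) and an at least 20-fold higher number from compound 1 to compound 4 (1.30 log units; beyond the scatter). The position, on an aromatic carbon of a six-membered aromatic ring of carbon only, is therefore not indifferent to what sits on it: replacing trifluoromethyl with phenoxymethyl, with its 8 heavy atoms and an aromatic ring, is enough to carry the series to the limit.

The compounds shown do not separate the contribution of the oxygen from that of the added ring, a question that methoxy, phenyl or benzyl at this place would address. As far as these compounds go, how far the true value of compound 4 lies past the limit also stays open.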